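Compound 3 and a change at one aromatic carbon

The source may report more compounds than this note shows. Statements on the series, on what has been measured and on what is new or still open speak of the compounds shown alone.

Values so far in a functional assay on BaF3 cells (Mus musculus) for inhibition, read by CCK-8 assay, with a stated time of 72 h; a higher number here means a weaker inhibitor of growth, a lower number a stronger inhibitor of growth

Compound 1 `CC(=O)Nc1cc(Oc2ccc(NC(=O)Nc3ccc(CN4CCN(C)CC4)c(C(F)(F)F)c3)cc2)ncn1` gives 50 nM
Compound 2 `CCN1CCN(Cc2ccc(NC(=O)Nc3ccc(Oc4cc(NC(C)=O)ncn4)cc3)cc2C(F)(F)F)CC1` gives 38 nM
Compound 3 `Cc1ccc(NC(=O)Nc2ccc(Oc3cc(N4CCNC[C@H]4C)ncn3)cc2)cc1C(F)(F)F` gives 9670 nM

Compound 3 (9670 nM) has the highest number of the three, well beyond the scatter from both others. Compound 4 `COCCNc1cc(Oc2ccc(NC(=O)Nc3ccc(C)c(C(F)(F)F)c3)cc2)ncn1` carries (2-methoxyethyl)amino in place of 2-methylpiperazin-1-yl on an aromatic carbon. For the measured compounds named here, the only measured step, a 1.3-fold lower number from compound 1 to compound 2 (0.12 log units; within the scatter), lies elsewhere in the molecule and does not test this change. Compound 1 and compound 2 differ from compound 3 in several places, so their far lower numbers offer only a loose hint. A moderately lower number is therefore expected in this assay, with wide uncertainty. The expected change is a 6.4-fold lower number from compound 3 to compound 4 (0.81 log units; beyond the scatter). For compound 4 the estimate is 1500 nM, with an expected range from 150 nM to 10000 nM.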

Compound 4, concentration for 50% growth inhibition: 7950 nM
Compound 4: the middle estimate sits 5.3-fold (0.72 log units) below what was measured; low and high end bracket the measured number.
By their numbers in this assay, from the lowest: compounds 2 and 1 (each within the scatter of the next); then compounds 4 and 3 (each within the scatter of the next).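

Placing (2-methoxyethyl)amino where 2-methylpiperazin-1-yl stood on this aromatic carbon gives a 1.2-fold lower number from compound 3 to compound 4 (0.09 log units; within the scatter). The two groups therefore cannot be told apart in this assay, even though one has a ring and a defined stereocentre and the other has neither. Nothing available explains this result.

Going by these compounds, it remains open whether a carboxylic acid or a longer ether chain at this position would shift the number beyond the scatter. Also open, on these data alone, is whether this same exchange would read alike on the core of compound 1.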